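This account rests on a few compounds, and the source may have more. Where it says the series, first, only, none or still open, it means among the compounds named here.

Three compounds have been measured in an assay on microsomes from brain for inhibition of Fatty-acid amide hydrolase 1 (Rattus norvegicus), read by fluorescence and HPLC, with a stated time of 60 min; on this read-out lower numbers stand for stronger inhibition and higher numbers for weaker inhibition:

Compound 1 `CCCCCCCCc1ccc(OCC(=O)Cn2nnc(-c3ccccc3)n2)cc1`: 24 nM
Compound 2 `CCCCCCCCc1ccc(OCC(=O)Cn2nnc(-c3cccc(Cl)c3)n2)cc1`: 24 nM
Compound 3 `CCCCCCCCc1ccc(OCC(=O)Cn2nnc(-c3ccc(S(=O)(=O)N(C)C)cc3)n2)cc1`: 590 nM

Compound 3 stands highest of the three numbers: a 25-fold higher number from compound 1 to compound 3 (1.39 log units; beyond the scatter) and a 25-fold higher number from compound 2 to compound 3 (1.39 log units; beyond the scatter), while no change at the digits printed from compound 1 to compound 2 (within the scatter). Compound 4 `CCCCCCCCc1ccc(OCC(=O)Cn2nnc(-c3ccncc3)n2)cc1` differs from compound 3 in one place: pyridin-4-yl in place of 4-(dimethylsulfamoyl)phenyl on an aromatic carbon. The two steps that bear on this are the ones leading to compound 3, both large and in the weakening direction, and both tied to the arrival of the dimethylsulfamoyl group; compound 1 and compound 2 show that a plain or chlorinated six-membered ring keeps the number low. For compound 4 the step is therefore expected to run back downward, roughly a 15-fold lower number from compound 3 to compound 4 (1.17 log units; beyond the scatter). Compound 4 is estimated at 40 nM, with a range from 12 nM to 150 nM.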

Compound 4, half-maximal inhibitory concentration: 24 nM
Compound 4: middle estimate off by 1.7-fold (0.22 log units), on the high side; the measured number falls inside the stated range.
By their numbers in this assay, from the lowest: compounds 1, 2 and 4 (each within the scatter of the next); then compound 3.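

Replacing the 4-(dimethylsulfamoyl)phenyl group with pyridin-4-yl fully reverses the loss seen in compound 3 (a 25-fold lower number from compound 3 to compound 4 (1.39 log units; beyond the scatter)). The new result also shows that this position accepts a six-membered aromatic ring with a hetero atom, since pyridin-4-yl matches both phenyl (no change at the digits printed from compound 1 to compound 4 (within the scatter)) and 3-chlorophenyl (no change at the digits printed from compound 2 to compound 4 (within the scatter)). Among these four compounds, only compound 3 stands apart.

As far as these compounds go, whether an amine or a carboxylic acid on this ring would keep the number low remains open. Nothing available explains why compound 3 gives the highest number.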